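Chloro in place of methyl: compound 1 to compound 4

The source may hold more compounds than are shown below. What is called first, only, known or untested is meant among the compounds shown, and "the series" means these compounds.

In an assay on isolated protein for inhibition of AP2-associated protein kinase 1 (Homo sapiens), with a stated time of 3 h, in the presence of a further agent that is not named here (on this read-out higher numbers stand for weaker inhibition and lower numbers for stronger inhibition), compound 1 `CC(=O)Nc1cc(-c2ccc(OC[C@@H](N)CC(C)C)c(C)c2)ccn1` gives 0.4 nM, the lowest of the three numbers recorded so far. Compound 3 `COC(=O)Nc1cc(-c2ccc(OC[C@@](C)(N)CC(C)C)c(Cl)n2)ccn1` gives 0.5 nM in this assay, a number that sits within the scatter of compound 1. Compound 2 `COC(=O)Nc1cc(-c2ccc(OC[C@@](C)(N)CC(C)C)nc2)ccn1` gives 28 nM in this assay, a gap from compound 1 that lies well beyond the scatter. Compounds 2 and 3 differ in more than one place, so their two values stand on their own and carry no single-change reading.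

Compound 4 `CC(=O)Nc1cc(-c2ccc(OC[C@@H](N)CC(C)C)c(Cl)c2)ccn1` is not yet measured in this assay. It differs from compound 1 by chloro in place of methyl on an aromatic carbon. Going by the values given here, no measured pair in the set shows this exchange alone, so there is no recorded step to lean on. Given the one-for-one swap of a single heavy atom with no change in ring, donor, acceptor or charge count, the step of a 1.3-fold higher number from compound 1 to compound 4 (0.10 log units; within the scatter) is expected to remain within the scatter, in no clear direction. Compound 4 is therefore expected to give 0.5 nM in this assay, with a range from 0.2 nM to 1.5 nM.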

Compound 4, half-maximal inhibitory concentration: 0.5 nM
Beside the measured number, compound 4's estimate shows no gap at the digits printed, within the range that was stated.
By their numbers in this assay, from the lowest: compounds 1, 3 and 4 (each within the scatter of the next); then compound 2.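

In this assay, going by these compounds alone, chloro in place of methyl on an aromatic carbon gives a 1.3-fold higher number from compound 1 to compound 4 (0.10 log units; within the scatter) and so supplies the first single-change reading. At this place, ortho to a (2-amino-4-methylpentyl)oxy group on the six-membered aromatic ring of carbon only, methyl and chloro cannot be told apart on this read-out, and both leave the compounds among the low numbers of the set. No measurement at hand bears on why the two groups read alike.

Going by these compounds, what a larger or more polar group would do at this place stays open, for example methoxy, nitrile or trifluoromethyl. On these data alone, it is also open whether the methyl-to-chloro exchange reads the same way on a core that carries a different amino ether chain or a methyl carbamate in place of the acetamide.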